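An Aryl Amide Exchange at the Carbonyl Carbon

The source may hold more compounds than are shown below. What is called first, only, known or untested is meant among the compounds shown, and "the series" means these compounds.

Compound 1 `CCN1CCN(c2cc(C)c3cc(NC(=O)c4cccc(C)c4)ccc3n2)CC1` was tested in a functional assay on MCF7 cells (Homo sapiens) for antiproliferative activity, read by MTT assay, with a stated time of 72 h (a lower number here means a stronger inhibitor, a higher number a weaker inhibitor), where compound 1 gives 7800 nM, the highest of the two numbers recorded. Compound 2 `Cc1cc(NCCN2CCCC2)nc2ccc(NC(=O)c3ccc(Cl)c(Cl)c3)cc12` gives 1280 nM in this assay, a lower number that lies beyond the scatter. Compound 3 `CCc1ccc(C(=O)Nc2ccc3nc(N4CCN(CC)CC4)cc(C)c3c2)cc1` is not yet measured; it differs from compound 1 by 4-ethylphenyl in place of 3-methylphenyl on a carbonyl carbon. For the measured compounds named here, no measured pair shows this change, so the expected step of a 1.3-fold lower number from compound 1 to compound 3 (0.11 log units; within the scatter) is modest, toward a lower number, or none beyond the scatter. Compound 3 is therefore estimated at 6000 nM, with a range from 2500 nM to 15000 nM.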

Compound 3, half-maximal inhibitory concentration: 3060 nM
For compound 3 the middle estimate is 2.0-fold (0.29 log units) above the measured one, within the range that was stated.
By their numbers in this assay, from the lowest: compound 2; then compound 3; then compound 1.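

In this assay, for the compounds shown here, the exchange of 3-methylphenyl for 4-ethylphenyl on a carbonyl carbon gives a 2.5-fold lower number from compound 1 to compound 3 (0.41 log units; beyond the scatter) and is the first single-place step at this position. It shows that this position responds to a change within a carbon-only aryl group, although the step is modest. Nothing on hand accounts for this step. A 4-methylphenyl or 3-ethylphenyl group here would separate the effect of chain length from that of where the chain sits. From the compounds shown here alone, how an amine or a carboxylic acid on this phenyl ring would read remains open.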